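The source may report more compounds than this note shows. Statements on the series, on what has been measured and on what is new or still open speak of the compounds shown alone.

Compound 1 `COc1cccc(/C=C/C(=O)/C=C/c2ccc(OCc3cn(CCOc4cc(=O)oc5ccccc45)nn3)c(OC)c2)c1`: 7130 nM
Compound 2 `COc1cc(/C=C/C(=O)/C=C/c2ccco2)ccc1OCc1cn(CCOc2cc(=O)oc3ccccc23)nn1`: 7870 nM

In a functional assay on THP-1 cells (Homo sapiens) for cytotoxicity, read by sulforhodamine B assay, with a stated time of 48 h (on this read-out lower numbers stand for stronger inhibition and higher numbers for weaker inhibition), compound 2 gives 7870 nM, the higher of the two numbers, yet within the scatter of compound 1 at 7130 nM. Compound 3 `COc1ccccc1/C=C/C(=O)/C=C/c1ccc(OCc2cn(CCOc3cc(=O)oc4ccccc34)nn2)c(OC)c1` carries one change from compound 2: 2-methoxyphenyl in place of furan-2-yl on a double-bonded chain carbon bound to a double-bonded chain carbon. Within the data shown here, only one measured step touches this place, a 1.1-fold higher number from compound 1 to compound 2 (0.04 log units; within the scatter), and it exchanges 3-methoxyphenyl for furan-2-yl. Among the measured compounds shown here, no compound with 2-methoxyphenyl has been measured yet. Given that small step, no shift beyond the scatter is expected. The expected step is a 1.1-fold lower number from compound 2 to compound 3 (0.05 log units; within the scatter). Compound 3 is estimated at 7000 nM, with an expected range of 3200 nM to 15000 nM.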

Compound 3, half-maximal inhibitory concentration: 7330 nM
Compound 3: middle estimate off by 1.0-fold (0.02 log units), on the low side; the measured number falls inside the stated range.
By their numbers in this assay, from the lowest: compounds 1, 3 and 2 (each within the scatter of the next).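

In this assay the exchange of furan-2-yl for 2-methoxyphenyl gives a 1.1-fold lower number from compound 2 to compound 3 (0.03 log units; within the scatter) and the exchange of 3-methoxyphenyl for 2-methoxyphenyl gives a 1.0-fold higher number from compound 1 to compound 3 (0.01 log units; within the scatter) and both steps lie within the scatter. At this place, then, neither the five-membered or six-membered aromatic ring nor the 2-methoxy or 3-methoxy form separates these three compounds. Nothing available explains this result. The compounds shown leave open whether a different kind of group here, such as an amine or a carboxylic acid, would move the number beyond the scatter.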